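The source may hold more compounds than are shown below. What is called first, only, known or untested is meant among the compounds shown, and "the series" means these compounds.

Measured compounds:
- compound 1, `COc1ccc(C(=O)/C=C/c2cn(-c3ccccc3)nc2-c2ccsc2)c(OC)c1OC`: 5800 nM
- compound 2, `O=C(/C=C/c1cn(-c2ccccc2)nc1-c1cccnc1)c1ccccn1`: 2100 nM

For the measured compounds named here, in a functional assay on HCT-116 cells (Homo sapiens) for inhibition, read by sulforhodamine B assay, with a stated time of 72 h (on this read-out lower numbers stand for stronger inhibition and higher numbers for weaker inhibition), compound 2 holds the lower of the two numbers so far; compound 1 sits higher, and that gap is beyond the scatter. Going by the values given here, the two differ in several places at once, so no single-change step between measured compounds can be read from them.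

Compound 3, `O=C(/C=C/c1cn(-c2ccccc2)nc1-c1cccnc1)c1c[nH]c2ccccc12`, follows from compound 2 by one change: 1H-indol-3-yl in place of pyridin-2-yl on a carbonyl carbon. Among the compounds with values here, no measured pair tracks this particular exchange, so the size of the step rests on judgement alone. The change keeps the enone and the core of compound 2 intact and swaps only the aryl ketone partner; the step from compound 2 to compound 3 in this assay is expected to be modest, most likely within the scatter, with a slight lean toward a lower number, as a 1.4-fold lower number from compound 2 to compound 3 (0.15 log units; within the scatter) states.

Compound 3 is expected to give 1500 nM in this assay, with a plausible range from 400 nM to 6000 nM.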

Compound 3, half-maximal inhibitory concentration: 6400 nM
Compound 3: the middle estimate sits 4.3-fold (0.63 log units) below what was measured, outside the stated range (above it).
By their numbers in this assay, from the lowest: compound 2; then compounds 1 and 3 (each within the scatter of the next).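

In this assay, for the compounds shown here, the group on the carbonyl carbon gives the first single-change reading: 1H-indol-3-yl in place of pyridin-2-yl gives a 3.0-fold higher number from compound 2 to compound 3 (0.48 log units; beyond the scatter), with the rest of compound 2 unchanged. This position is therefore not neutral to the exchange, which brings in a second aromatic ring and a hydrogen-bond donor and removes a hydrogen-bond acceptor. No measured property is available to bear on this step.

One exchange does not separate the added ring from the added donor, so an N-methylindol-3-yl group or a plain phenyl on the carbonyl carbon would be informative. Also open, as far as these compounds go, is how an amine or a carboxylic acid on the pyridine ring would read at this position.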